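The source may report more compounds than this note shows. Statements on the series, on what has been measured and on what is new or still open speak of the compounds shown alone.

Measured in a functional assay on HepG2 cells (Homo sapiens) for antiproliferative activity, read by MTT assay, with a stated time of 72 h; on this read-out lower numbers stand for stronger inhibition and higher numbers for weaker inhibition:
- compound 1 `NC1=NC2(CCSCC2)N(OCCCOc2cccc(Cl)c2)C(N)=N1`: 90 nM
- compound 2 `NC1=NC2(CCSCC2)N(OCCCOc2ccc(Br)cc2)C(N)=N1`: 1400 nM
- compound 3 `NC1=NC2(CCSCC2)N(OCCCOc2cccc(Cl)c2Cl)C(N)=N1`: 50 nM

Compound 3 is not separated from its nearest neighbour, with a 1.8-fold lower number from compound 1 to compound 3 (0.26 log units; within the scatter), while the remaining measured compound lies far off, with a 28-fold lower number from compound 2 to compound 3 (1.45 log units; beyond the scatter). The unmeasured compound 4 `NC1=NC2(CCSCC2)N(OCCCOc2cc(Cl)c(Cl)cc2Cl)C(N)=N1` keeps the shared core and changes one group: 2,4,5-trichlorophenyl in place of 2,3-dichlorophenyl on an oxygen on a saturated carbon.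

Two kinds of evidence bear on this change. Adding a chloro on an aromatic carbon gave a 1.8-fold lower number from compound 1 to compound 3 (0.26 log units; within the scatter), which lies within the scatter, so one more chlorine alone suggests little movement. Among the measured compounds shown here, compound 2, at 1400 nM, is the only measured compound whose group name carries a 4, as the entering name does, and both large steps touch it: a 16-fold higher number from compound 1 to compound 2 (1.19 log units; beyond the scatter) and a 28-fold lower number from compound 2 to compound 3 (1.45 log units; beyond the scatter). For the measured compounds named here, one compound with bromo rather than chloro is a weak guide, and the data hold no direct precedent for this group. It still points to a moderate move toward a higher number in this assay, smaller than those two large steps.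

The estimated step is a 3.2-fold higher number from compound 3 to compound 4 (0.51 log units; beyond the scatter). For compound 4 the expected value is 160 nM, with an estimated range from 40 nM to 700 nM.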

Compound 4, half-maximal inhibitory concentration: > 100000 nM
Compound 4: no number, only a limit; the forecaster's own chance of this, stated with the estimate: 3%; at least 620-fold (2.79 log units) between middle value and limit.
By their numbers in this assay, from the lowest: compounds 3 and 1 (each within the scatter of the next); then compound 2. At a limit, above all of these: compound 4.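

Among the compounds shown here, compound 4 gives no number in this assay, only a limit: the limit of > 100000 nM in this assay, at which 1 of the 4 values shown sits. The earlier compounds gave no sign that chlorine on this phenyl group could carry such a penalty, as the one chlorine addition among them stayed within the scatter, whereas the change to 2,4,5-trichlorophenyl on an oxygen on a saturated carbon gives an at least 2000-fold higher number from compound 3 to compound 4 (3.30 log units; beyond the scatter). The same group also stands far from the two other aryl groups, with an at least 71-fold higher number from compound 2 to compound 4 (1.85 log units; beyond the scatter) and an at least 1100-fold higher number from compound 1 to compound 4 (3.04 log units; beyond the scatter), so across these four compounds the count of chlorine atoms alone does not track the read-out.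

The compounds shown leave open which part of the change carries the loss, as the 2,4,5-trichlorophenyl group differs from the 2,3-dichlorophenyl group in more than one ring position, and a 2,4-dichlorophenyl or 2,5-dichlorophenyl group would help to separate these. They also leave open whether a 4-chlorophenyl group would behave like the 4-bromophenyl group of compound 2, and how a methoxy group or a longer chain would fare on this part of the molecule.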